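A few compounds are considered here, and "the series" means these few. Any claim that something is new, unique, unknown or untested is made for them only; others in the source may bear on it.

Values in a functional assay on CHO cells for agonist activity at Free fatty acid receptor 1 (Homo sapiens) (a lower number here means that less compound is needed, a higher number that more compound is needed for the effect), for the shared core:

compound 1, `O=C(O)COc1ccc(NCc2cccc(Oc3ccccc3)c2)cc1`: 2040 nM
compound 2, `O=C(O)[C@@H]1C[C@H]1c1ccc(NCc2cccc(Oc3ccccc3)c2)cc1`: 562 nM
compound 3, `O=C(CCc1ccc(NCc2cccc(Oc3ccccc3)c2)cc1)N1CCCC1`: 115 nM

Compound 3 holds the lowest number of the three, with steps a 4.9-fold lower number from compound 2 to compound 3 (0.69 log units; beyond the scatter) and an 18-fold lower number from compound 1 to compound 3 (1.25 log units; beyond the scatter) both beyond the scatter. Compound 4, `CC(C)NC(=O)[C@H]1C[C@@H]1c1ccc(NCc2cccc(Oc3ccccc3)c2)cc1`, is the rearranged analogue: 2-(isopropylcarbamoyl)cyclopropyl in place of 2-((pyrrolidin-1-yl)carbonyl)ethyl on an aromatic carbon.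

Among the compounds with values here, two measured steps bear on this. The cyclopropyl ring itself is supported by a 3.6-fold lower number from compound 1 to compound 2 (0.56 log units; beyond the scatter), a modest gain, though the groups compared there were both acids. The amide is supported by a 4.9-fold lower number from compound 2 to compound 3 (0.69 log units; beyond the scatter), but that step changed the linker and the acid-to-amide at once, so the amide's own share is not separable. Within the data shown here, no step compares the isopropyl amide with the pyrrolidine amide, and no step holds the amide fixed while swapping the ethyl chain for the cyclopropyl ring. The two parts of the change pull in opposite, unquantified directions; a small step is expected, a 1.7-fold higher number from compound 3 to compound 4 (0.24 log units; within the scatter), most likely within or near the scatter. Compound 4 is estimated at 200 nM, in a range of 50 nM to 800 nM.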

Compound 4, half-maximal effective concentration: 12.6 nM
Estimate against measurement, compound 4: 16-fold (1.20 log units) above; measured number outside the range, below it.
By their numbers in this assay, from the lowest: compound 4; then compound 3; then compound 2; then compound 1.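

Compound 4 and compound 3 carry the same atoms, so rejoining them as 2-(isopropylcarbamoyl)cyclopropyl in place of 2-((pyrrolidin-1-yl)carbonyl)ethyl, para to a large group, is enough to give a 9.1-fold lower number from compound 3 to compound 4 (0.96 log units; beyond the scatter); the change also brings a hydrogen-bond donor and two defined stereocentres. Within the data shown here, for the first time, the cyclopropyl ring stands on both sides of a step, and the isopropyl amide in place of the carboxylic acid gives a 45-fold lower number from compound 2 to compound 4 (1.65 log units; beyond the scatter), while the whole span of the series reaches a 160-fold lower number from compound 1 to compound 4 (2.21 log units; beyond the scatter). Nothing measured here explains these steps.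

How the drop from compound 3 divides among the ring, the amide hydrogen and the isopropyl group remains open, since a pyrrolidine amide on the cyclopropyl ring and an isopropyl amide on the ethyl chain lie outside the compounds shown. Also open, from the compounds shown here alone, is how a cyclobutyl ring or a tert-butyl amide would read at this position.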